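The source may report more compounds than this note shows. Statements on the series, on what has been measured and on what is new or still open speak of the compounds shown alone.

Measured in a functional assay on PC-3 cells (Homo sapiens) for antiproliferative activity, read by CCK-8 assay, with a stated time of 6 days; a lower number here means a stronger inhibitor, a higher number a weaker inhibitor:
- Compound 1 `CCN(c1ccc(C#N)c(Cl)c1)c1cc(-c2cncnc2)ccc1C`: > 30000 nM
- Compound 2 `CCN(c1ccc(C#N)c(Cl)c1)c1cc(-c2ccc(F)nc2)ccc1C`: > 30000 nM
- Compound 3 `CCN(c1ccc(C#N)c(Cl)c1)c1cc(C2=CCCCC2)ccc1C`: "not determined" (no result reported)

Compound 1 gives > 30000 nM, which is a limit of the assay and not a number. Compound 2 gives > 30000 nM, again a limit. Compound 3 has no number of its own, its entry reading "not determined" (no result reported), so its place in this assay is open.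

Compound 4 `CCN(c1ccc(C#N)c(Cl)c1)c1cc(-c2c[nH]nc2C)ccc1C` follows from compound 3 by one change: 3-methyl-1H-pyrazol-4-yl in place of cyclohex-1-en-1-yl on an aromatic carbon. The new group sits meta to a large group and para to a methyl group.

Among the measured compounds shown here, the only measured step nearby is a step that the two limits leave unreadable from compound 1 to compound 2, and it gives no size to carry over. For the measured compounds named here, compound 3 offers no number to step from, so no step of any size or direction can be expected from it in this assay. The remaining guide is the limit of > 30000 nM in this assay, at which 2 of the 3 values shown sit, which suggests that compound 4, with its aromatic group in this place, will also be a weak inhibitor.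

Compound 4 is estimated at 30000 nM, with an expected range from 8000 nM to 60000 nM.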

Compound 4, half-maximal inhibitory concentration: 9030 nM
The estimate for compound 4 lay 3.3-fold (0.52 log units) above the measured number, and the stated range covers the measured number.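

Compound 4 shows that this position, para to a methyl group on the shared core, can carry a group that gives a readable number in this assay, which neither compound 1 nor compound 2 did: the limit of > 30000 nM in this assay, at which 2 of the 4 values shown sit. With 3-methyl-1H-pyrazol-4-yl entering in place of 6-fluoropyridin-3-yl there is an at least 3.3-fold lower number from compound 2 to compound 4 (0.52 log units; beyond the scatter), and with it entering in place of pyrimidin-5-yl there is an at least 3.3-fold lower number from compound 1 to compound 4 (0.52 log units; beyond the scatter). Both steps start from a limit of the assay, so each gives only a least size.

The compounds shown leave open whether the methyl on the new ring matters, as a plain 1H-pyrazol-4-yl group does not stand beside compound 4. Also open, on these data alone, is how compound 4 compares with compound 3, which has no result in this assay.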